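This account rests on a few compounds, and the source may have more. Where it says the series, first, only, none or still open, it means among the compounds named here.

Three measured compounds share one core and differ only in the group carried at one end of it. In an assay on isolated protein for binding affinity to secreted frizzled-related protein 1 (Homo sapiens), read by fluorescence (on this read-out higher numbers stand for weaker inhibition and lower numbers for stronger inhibition), compound 1 `O=C(Cn1ccnc1)N1CCC(NS(=O)(=O)c2cc(S(=O)(=O)c3ccccc3)ccc2C(F)(F)F)CC1` gives 30 nM. Compound 2 `CC(C)C(=O)N1CCC[C@H]1C(=O)N1CCC(NS(=O)(=O)c2cc(S(=O)(=O)c3ccccc3)ccc2C(F)(F)F)CC1` gives 40 nM in this assay, and compound 3 `O=C([C@@H]1CCCN1C(=O)N1CCOCC1)N1CCC(NS(=O)(=O)c2cc(S(=O)(=O)c3ccccc3)ccc2C(F)(F)F)CC1` gives 40 nM in this assay. The step of a 1.3-fold higher number from compound 1 to compound 2 (0.12 log units; within the scatter) and the step of no change at the digits printed from compound 2 to compound 3 (within the scatter) both stay within the scatter, so the three numbers cannot be told apart: compound 3 matches compound 2 exactly at the digits shown and sits within the scatter of compound 1.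

Compound 4 `CC(C)(C)CCN1CCC[C@H]1C(=O)N1CCC(NS(=O)(=O)c2cc(S(=O)(=O)c3ccccc3)ccc2C(F)(F)F)CC1` is the next member of the series. Its change from compound 3 is 3,3-dimethylbutyl in place of (morpholin-4-yl)carbonyl on an amine nitrogen in a ring. Both measured steps altered this same end of the molecule without moving the number beyond the scatter, which suggests that quite different groups are tolerated there. Among the compounds with values here, neither of those steps, however, removed a carbonyl from the amine nitrogen in a ring and left a 3,3-dimethylbutyl in its place, so the present change goes further than anything yet measured, and no step speaks to it directly. On that basis the expected step in this assay is a 1.1-fold higher number from compound 3 to compound 4 (0.05 log units; within the scatter), with no firm direction. Compound 4 is therefore estimated at 45 nM, with a likely range from 15 nM to 150 nM.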

Compound 4, half-maximal inhibitory concentration: 30 nM
Compound 4: middle estimate off by 1.5-fold (0.18 log units), on the high side; the range from low to high includes it.
By their numbers in this assay, from the lowest: compounds 1, 4, 2 and 3 (each within the scatter of the next).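

In this assay, the amine nitrogen in the five-membered ring does not need a carbonyl: placing 3,3-dimethylbutyl there instead of (morpholin-4-yl)carbonyl gives a 1.3-fold lower number from compound 3 to compound 4 (0.12 log units; within the scatter), even though the entering group has no ring and 0 hydrogen-bond acceptors, while the leaving group has one ring and 2. The comparison with the other carbonyl-bearing compound reads the same, at a 1.3-fold lower number from compound 2 to compound 4 (0.12 log units; within the scatter), and replacing the whole group on the carbonyl carbon of compound 1 gives no change at the digits printed from compound 1 to compound 4 (within the scatter), so this end of the molecule has now carried an imidazole-containing group, two acylated rings and a purely carbon chain, with all four numbers within the scatter of one another. Nothing shown gives a reason for this tolerance.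

From the compounds shown here alone, what remains open is whether the same nitrogen would stay level with a bare hydrogen, or with a chain ending in an amine or a carboxylic acid. The compounds also leave open how a longer chain there would read, and all four share the rest of the core, so they say nothing about changes elsewhere.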